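Trifluoromethyl in place of fluoro: what to expect

A few compounds are considered here, and "the series" means these few. Any claim that something is new, unique, unknown or untested is made for them only; others in the source may bear on it.

In a functional assay on Jurkat cells (Homo sapiens) for inhibition, read by MTT assay, with a stated time of 72 h (a higher number here means a weaker inhibitor of growth, a lower number a stronger inhibitor of growth), the measured compounds gave the following:
Compound 1 `COC(=O)c1nc(C)n(-c2ccc(F)cc2)n1`: 8700 nM
Compound 2 `COC(=O)c1nc(C(C)C)n(-c2ccc(F)cc2)n1`: > 100000 nM, a limit of the assay, not a number
Compound 3 `COC(=O)c1nc(-c2ccc[nH]2)n(-c2ccc(F)cc2)n1`: 9010 nM

Compound 3 and compound 1 lie within the scatter of each other, as a 1.0-fold higher number from compound 1 to compound 3 (0.02 log units; within the scatter) shows. Compound 2 sits at the limit of > 100000 nM in this assay, at which 1 of the 3 values shown sits, so an at least 11-fold higher number from compound 1 to compound 2 (1.06 log units; beyond the scatter) and an at least 11-fold lower number from compound 2 to compound 3 (1.04 log units; beyond the scatter) are both large. Compound 4 `COC(=O)c1nc(-c2ccc[nH]2)n(-c2ccc(C(F)(F)F)cc2)n1` differs from compound 3 by trifluoromethyl in place of fluoro on an aromatic carbon. Among the compounds with values here, none of the measured steps touches this part of the molecule; all three alter the group on an aromatic carbon of the shared core. There is therefore no measured basis for a direction, and the expected step of a 1.0-fold lower number from compound 3 to compound 4 (0.00 log units; within the scatter) is none beyond the scatter. Compound 4 is expected to give 9000 nM, between 3000 nM and 30000 nM.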

Compound 4, concentration for 50% growth inhibition: > 100000 nM
Compound 4: no number, only a limit; the forecaster's own chance of this, stated with the estimate: 10%; middle value at least 11-fold (1.04 log units) away from the limit.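

This place, para to a large group, is not indifferent to change: with the 1H-pyrrol-2-yl group held fixed, trifluoromethyl in place of fluoro gives an at least 11-fold higher number from compound 3 to compound 4 (1.04 log units; beyond the scatter) in this assay. The value of compound 4, > 100000 nM, is a limit of the assay, not a number: the limit of > 100000 nM in this assay, at which 2 of the 4 values shown sit.

It remains open how a chloro, methoxy or amine group would fare at this place, since fluoro and trifluoromethyl are the only groups shown there. Also open, going by these compounds, is whether the same change would give a similar step with the methyl group of compound 1.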